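This account rests on a few compounds, and the source may have more. Where it says the series, first, only, none or still open, it means among the compounds named here.

Two measured compounds frame this account. Compound 1 `Clc1ccc(-c2cc(-c3ccco3)nc(-c3cccs3)c2)o1` gives 16% in an assay on isolated protein for inhibition of DNA topoisomerase 1 (Homo sapiens), tested at 100 uM; a higher number here means a stronger effect of the compound at the concentration tested, a lower number a weaker effect. Compound 2 `Cc1ccccc1-c1cc(-c2ccc(Cl)o2)cc(-c2ccsc2)n1` gives 6.7% in this assay and so carries the lower of the two numbers, yet the gap to compound 1 lies within the usual scatter of this kind of measurement, so the two cannot be ranked against each other.

Compound 3 `Cc1ccc(-c2cc(-c3ccc(Cl)o3)cc(-c3ccsc3)n2)cc1` has not been measured. It holds the same atoms as compound 2, joined differently: 4-methylphenyl in place of 2-methylphenyl on an aromatic carbon. Going by the values given here, no measured pair shows what such a change does in this assay, so there is no step in the data to lean on. Compound 3 is therefore expected to give about the same reading as compound 2, with a step of a number 3.3 percentage points higher from compound 2 to compound 3 (within the scatter) that does not exceed the scatter in either direction. The estimate for compound 3 in this assay is 10%, within a range from 0% to 25%.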

Compound 3, a percentage reported as inhibition, at one concentration (the size of the read-out at that concentration, not a potency): 2.6%
Compound 3: the middle estimate sits 7.4 percentage points above what was measured, and the stated range covers the measured number.
By their numbers in this assay, from the lowest: compounds 3, 2 and 1 (each within the scatter of the next, the first and the last beyond it).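

In this assay, going by these compounds alone, 4-methylphenyl in place of 2-methylphenyl on the aromatic carbon next to the ring nitrogen gives a number 4.1 percentage points lower from compound 2 to compound 3 (within the scatter), and this is the first pair that differs in one place. For these two compounds, then, where the methyl group sits on this phenyl ring does not separate the readings beyond the scatter. Nothing shown here offers an explanation for this result.

The compounds shown leave open whether a different group on this phenyl ring, such as an amine or a carboxylic acid, would shift the reading beyond the scatter. They also leave open whether this change would behave the same way with the other groups on the shared core held differently, as compound 1 differs from both in more than one place.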